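The source may hold more compounds than are shown below. What is called first, only, known or untested is meant among the compounds shown, and "the series" means these compounds.

Compound 1 `O=C1CSC(=O)N1C[C@H]1CN(c2ccc(-n3cc(-c4ccccn4)cn3)c(F)c2)C(=O)O1` carries a 2,4-dioxo-1,3-thiazolidin-3-yl group on a saturated chain carbon bound to a saturated ring carbon; in an ADME assay on HEK293-A cells (Homo sapiens) for cytotoxicity, read by MTT assay, with a stated time of 48 h (a lower number here means a stronger inhibitor, a higher number a weaker inhibitor), compound 1 gives 283 ug/mL. Compound 2 `O=C1O[C@@H](Cn2ccnc2)CN1c1ccc(-n2cc(-c3ccccn3)cn2)c(F)c1` has 1H-imidazol-1-yl in that place. In this assay compound 2 reaches only the limit of the measurement, > 400 ug/mL. The step is thus known only as a floor, an at least 1.4-fold higher number from compound 1 to compound 2 (0.15 log units; that floor lies within the scatter), and the limit of > 400 ug/mL in this assay, at which 1 of the 2 values shown sits, marks where compound 2 sits. Compound 3 `O=C1O[C@@H](Cn2ccnn2)CN1c1ccc(-n2cc(-c3ccccn3)cn2)c(F)c1` is the next change at the same place: 1H-1,2,3-triazol-1-yl in place of 1H-imidazol-1-yl on a saturated chain carbon bound to a saturated ring carbon. Within the data shown here, the one measured step that bears on it is the exchange of the ring group on that chain carbon from compound 1 to compound 2, whose floor lies within the scatter, so no step beyond the scatter is expected here in either direction. The step that this estimate means is a number no higher from compound 2 to compound 3 (the limit leaves the size open). Compound 3 is expected to give 400 ug/mL, between 250 ug/mL and 650 ug/mL, quite possibly again as a limit only.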

Compound 3, half-maximal inhibitory concentration: 225 ug/mL
Estimate against measurement, compound 3: 1.8-fold (0.25 log units) above; measured number below the stated range.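

Among these compounds, at this place, on a saturated chain carbon bound to a saturated ring carbon, compound 3 gives the exchange of 1H-imidazol-1-yl for 1H-1,2,3-triazol-1-yl a first reading in this assay (an at least 1.7-fold lower number from compound 2 to compound 3 (0.24 log units; that floor lies within the scatter)). That step stands only as a floor because compound 2 sits at a limit of the measurement: the limit of > 400 ug/mL in this assay, at which 1 of the 3 values shown sits. The exchange of 2,4-dioxo-1,3-thiazolidin-3-yl for 1H-1,2,3-triazol-1-yl (a 1.3-fold lower number from compound 1 to compound 3 (0.10 log units; within the scatter)) stays within the scatter, so no change at this place has yet produced a step beyond it.

As far as these compounds go, how much larger the step from the limit of compound 2 really is remains open. So does whether a group such as an amine, a carboxylic acid or a longer chain at this place would move the number beyond the scatter.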